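The source may hold more compounds than are shown below. What is called first, only, known or untested is meant among the compounds shown, and "the series" means these compounds.

In a functional assay on MDA-MB-231 cells (Homo sapiens) for antiproliferative activity, read by MTT assay, with a stated time of 72 h (on this read-out lower numbers stand for stronger inhibition and higher numbers for weaker inhibition), compound 1 `CC1=CC[C@H]2[C@H](CC[C@]2(C)O)C(C)(C)[C@@H]1CC[C@H]1[C@]2(C)CC[C@H](OC(=O)c3ccc(Cl)cc3)C(C)(C)O[C@H]2CC[C@@]1(C)O` gives 10300 nM, compound 2 `CC1=CC[C@H]2[C@@H]1CC=C(C)[C@@H](CC[C@H]1[C@]3(C)CC[C@H](OC(=O)c4ccccc4)C(C)(C)O[C@H]3CC[C@@]1(C)O)C2(C)C` gives 18400 nM and compound 3 `CC1=CC[C@H]2[C@@H]1CC=C(C)[C@@H](CC[C@H]1[C@]3(C)CC[C@H](OC(=O)c4ccncc4)C(C)(C)O[C@H]3CC[C@@]1(C)O)C2(C)C` gives 19100 nM. All three numbers lie within the usual scatter of one another, so compound 1 cannot be told apart from the other two on this evidence.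

Compound 4 `CC1=CC[C@H]2[C@H](CC[C@]2(C)O)C(C)(C)[C@@H]1CC[C@H]1[C@]2(C)CC[C@H](OC(=O)c3ccc(Cl)c(Cl)c3)C(C)(C)O[C@H]2CC[C@@]1(C)O` keeps the core of compound 1 and turns its 4-chlorophenyl into 3,4-dichlorophenyl, with chloro in place of hydrogen on an aromatic carbon.

Among the measured compounds shown here, no measured pair tests this exact change. The nearest evidence is another swap on the group attached to the carbonyl carbon, pyridin-4-yl in place of phenyl, which gives a 1.0-fold higher number from compound 2 to compound 3 (0.02 log units; within the scatter). That single step hardly moves the number, and it offers no reason to expect a real shift in either direction in this assay.

The expected result is therefore a 1.1-fold lower number from compound 1 to compound 4 (0.04 log units; within the scatter), which would mean no change beyond the scatter. For compound 4 the estimated value is 9500 nM, with an expected range from 4500 nM to 20000 nM.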

Compound 4, half-maximal inhibitory concentration: 8100 nM
Compound 4: the middle estimate sits 1.2-fold (0.07 log units) above what was measured; the measured number falls inside the stated range.
By their numbers in this assay, from the lowest: compounds 4, 1, 2 and 3 (each within the scatter of the next, the first and the last beyond it).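

Placing a chloro on the aromatic carbon ortho to the existing chloro group and meta to a large group gives a 1.3-fold lower number from compound 1 to compound 4 (0.10 log units; within the scatter) in this assay. The earlier step replaced the whole phenyl with pyridin-4-yl on a different core, whereas this pair tests a single added atom on the ring of compound 1. On this evidence, going from 4-chlorophenyl to 3,4-dichlorophenyl leaves the antiproliferative read-out indistinguishable, and no separate measurement is available to help interpret this result.

The compounds shown leave open whether an amine or a carboxylic acid on this same aromatic carbon would move the number beyond the scatter. They also leave open whether the same chloro would behave alike on the core of compound 2.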